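The source may report more compounds than this note shows. Statements on the series, on what has been measured and on what is new or still open speak of the compounds shown alone.

Working notes on the amides of the shared core. In a functional assay on MCF7 cells (Homo sapiens) for antiproliferative activity, read by MTT assay, with a stated time of 72 h (a lower number here means a stronger inhibitor, a higher number a weaker inhibitor), compound 1 (`CCn1cc(C(CC)(CC)c2ccc(C#CC(O)(CC)CC)c(C)c2)cc1C(=O)NCC(=O)OC`) gives 26500 nM and compound 2 (`CCn1cc(C(CC)(CC)c2ccc(C#CC(O)(CC)CC)c(C)c2)cc1C(=O)N[C@H](C(=O)O)C(C)C`) gives 12600 nM. Going by the values given here, compound 2 therefore holds the lower of the two numbers so far, and the gap between them is beyond the scatter.

Compound 3 (`CCn1cc(C(CC)(CC)c2ccc(C#CC(O)(CC)CC)c(C)c2)cc1C(=O)N[C@@H](C)CO`) is still to be measured in this assay. Its difference from compound 2 is 1-(hydroxymethyl)ethyl in place of 1-carboxy-2-methylpropyl on an amide-type nitrogen.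

Among the compounds with values here, only one measured step bears on this change, since it also swaps the group on that nitrogen: a 2.1-fold lower number from compound 1 to compound 2 (0.32 log units; beyond the scatter). Within the data shown here, that step is modest, and no measured compound yet carries the entering group, so the evidence is thin. Among the measured compounds shown here, a step no larger than this one is expected, leaning to a higher number, as compound 2 at 12600 nM is the low end of the series so far. The expected change is a 1.4-fold higher number from compound 2 to compound 3 (0.15 log units; within the scatter). Compound 3 is estimated at 18000 nM, with an expected range of 7500 nM to 42000 nM.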

Compound 3, half-maximal inhibitory concentration: 1910 nM
Estimate against measurement, compound 3: 9.4-fold (0.97 log units) above; the measured number lies below the stated range.
By their numbers in this assay, from the lowest: compound 3; then compound 2; then compound 1.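

In this assay, the group on the amide-type nitrogen can move the number much further than the earlier pair showed: 1-(hydroxymethyl)ethyl in place of 1-carboxy-2-methylpropyl gives a 6.6-fold lower number from compound 2 to compound 3 (0.82 log units; beyond the scatter), and in place of (methoxycarbonyl)methyl it gives a 14-fold lower number from compound 1 to compound 3 (1.14 log units; beyond the scatter). Compound 3 therefore holds the lowest number of the three, beyond the scatter against both other compounds, and the entering group is the smaller one by count, with 4 heavy atoms against 7, while the hydrogen-bond donor and acceptor counts stay the same across the change from compound 2. Going by these compounds alone, no measurement bears on why this change lowers the number so far.

The change from compound 2 alters the end group and the branching of the chain together, so the compounds shown do not separate the contribution of the hydroxymethyl from that of the shorter chain. Also open, going by these compounds, is whether a primary amine in place of the hydroxyl, a longer chain carrying the hydroxyl, or the opposite stereocentre of 1-(hydroxymethyl)ethyl would hold the number of compound 3.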